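This account rests on a few compounds, and the source may have more. Where it says the series, first, only, none or still open, it means among the compounds named here.

Compound 1 `COc1ccc([C@@H]2Oc3cc(OC)c(O)c(OC)c3C(=O)[C@@H]2O)cc1OC` belongs to a small set of three compounds that share one core and differ only in the pattern of hydroxy and methoxy groups on their aromatic rings. In a functional assay on PC-12 cells (Rattus norvegicus) for cytotoxicity, read by MTT assay, with stated times of 2 h and 4 h, tested at 8 ug/mL (on this read-out higher numbers stand for a stronger effect at the one concentration tested and lower numbers for a weaker effect), compound 1 gives 2.9%, the highest of the three numbers shown, although its gaps to both neighbours lie within the scatter. Compound 2 `COc1cc([C@@H]2Oc3cc(OC)c(O)c(OC)c3C(=O)[C@@H]2O)ccc1O` gives -0.2% in this assay, and compound 3 `COc1cc2c(c(OC)c1OC)C(=O)[C@H](O)[C@@H](c1ccc(O)cc1)O2` gives -1.4%. Going by the values given here, the only single-point step among the measured compounds is a number 3.1 percentage points lower from compound 1 to compound 2 (within the scatter), a change that does nothing the scatter would not explain.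

Compound 4 `COc1ccc([C@@H]2Oc3cc(OC)c(OC)c(OC)c3C(=O)[C@@H]2O)cc1OC` has not yet been measured. It differs from compound 1 by methyl in place of hydrogen on an oxygen on an aromatic ring. Among the compounds with values here, the one measured step that bears on it is the reverse kind of change on a different ring, and it stayed within the scatter, so no shift beyond the scatter is expected in this assay: the estimated step is a number 0.1 percentage points higher from compound 1 to compound 4 (within the scatter). Compound 4 is therefore expected to give 3%, within a range from -7% to 13%.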

Compound 4, a percentage reported as activity, at one concentration (the size of the read-out at that concentration, not a potency): -2.5%
Compound 4: the middle estimate sits 5.5 percentage points above what was measured, and the stated range covers the measured number.
By their numbers in this assay, from the lowest: compounds 4, 3, 2 and 1 (each within the scatter of the next).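

Turning the hydroxy into a methoxy at this position gives, in this assay, a step that is a number 5.4 percentage points lower from compound 1 to compound 4 (within the scatter), so this oxygen, like the one changed on the other ring in a number 3.1 percentage points lower from compound 1 to compound 2 (within the scatter), shows no effect of the change that the scatter would not explain. Compound 4 adds a second place to that picture, as a hydroxy and a methoxy at this position cannot be told apart on this read-out at the one concentration tested. No measurement shown offers any explanation for this result.

As far as these compounds go, whether a larger change at this oxygen, such as a longer chain in place of the methyl or a chain ending in an amine or a carboxylic acid, would move the number beyond the scatter stays open. Also open, from the compounds shown here alone, is whether the hydroxy and methoxy forms would separate at any other concentration.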